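Weak inhibitors around a shared core: a bromo-methyl variant

The compounds below may be only part of what the source reports. "The series", "measured", "known", "first", "only" and "open" are said of these compounds alone.

Measured compounds:
compound 1 `Cc1ccc(C)c(Nc2c(-c3ccc4[nH]nc(C)c4c3)nc3cnc(N4CCN(C)CC4)cn23)c1` — in a functional assay on CWR22R cells (Homo sapiens) for inhibition, with a stated time of 120 h (on this read-out higher numbers stand for weaker inhibition and lower numbers for stronger inhibition), compound 1 gives "not determined" (no result reported)
compound 2 `Cc1n[nH]c2ccc(-c3nc4cnc(N5CCN(C)CC5)cn4c3Nc3ccc(Cl)cc3F)cc12` — 14100 nM

Compound 2 holds the only number shown in this assay, and that number, 14100 nM, marks it as a weak inhibitor. Compound 3 `Cc1cc(Br)ccc1Nc1c(-c2ccc3[nH]nc(C)c3c2)nc2cnc(N3CCN(C)CC3)cn12` differs from compound 2 by 4-bromo-2-methylphenyl in place of 4-chloro-2-fluorophenyl on a nitrogen on an aromatic ring. Among the measured compounds shown here, no step between measured compounds is available to size this change, so the expected step from compound 2 to compound 3 is a 1.2-fold lower number from compound 2 to compound 3 (0.07 log units; within the scatter), which lies within the usual scatter. Compound 3 is therefore estimated at 12000 nM, with a range from 3500 nM to 40000 nM.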

Compound 3, half-maximal inhibitory concentration: 6510 nM
The estimate for compound 3 lay 1.8-fold (0.27 log units) above the measured number; low and high end bracket the measured number.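

In this assay, the change from (4-chloro-2-fluorophenyl)amino to (4-bromo-2-methylphenyl)amino gives a 2.2-fold lower number from compound 2 to compound 3 (0.34 log units; beyond the scatter), the first sign that the number responds to the phenyl group at this position. The step is modest, and the two groups have the same count of heavy atoms. Nothing measured here accounts for the step.

Chlorine gives way to bromine and fluorine to methyl in one step, so which exchange carries the shift remains open. So does the effect of an amine or a carboxylic acid on this phenyl ring.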